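The compounds below may be only part of what the source reports. "The series", "measured", "known", "first", "only" and "open" are said of these compounds alone.

In a functional assay on HO8910 cells (Homo sapiens) for inhibition, read by MTT assay, with a stated time of 24 h, tested at 0.1 ug/mL (a higher number here means more inhibition of growth at the concentration tested, a lower number less inhibition of growth), compound 1 `O=C(O)CCCCC(CCSC(=O)c1ccccc1)SC(=O)c1ccccc1` is recorded as "not active" (no number reported) with no number reported. Compound 2 `O=C(CCCCC(CCSC(=O)c1ccccc1)SC(=O)c1ccccc1)Nc1cccc(Cl)c1` gives 9.02% in this assay and this is the only number shown there, so its standing can be judged against no other measured value. Compound 3 `O=C(CCCCC(CCSC(=O)c1ccccc1)SC(=O)c1ccccc1)Nc1ccc(Cl)cc1` has not yet been measured. Its difference from compound 2 is 4-chlorophenyl in place of 3-chlorophenyl on an amide-type nitrogen and amounts to 4-chlorophenyl in place of 3-chlorophenyl on an amide-type nitrogen, with the same atoms joined differently. Among the compounds with values here, no step between measured compounds is available to size such a change, so no direction is favoured and no shift beyond the scatter is expected in this assay here. The estimated a number 1 percentage points higher from compound 2 to compound 3 (within the scatter) is therefore expected to remain within the scatter. Compound 3 is estimated to give 10% with an expected range from 2% to 22% across repeated measurements.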

Compound 3, percent growth inhibition at one concentration: 3.68%
Compound 3: the middle estimate sits 6.3 percentage points above what was measured; the measured number falls inside the stated range.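

In this assay, within the data shown here, the change from 3-chlorophenyl to 4-chlorophenyl on the amide-type nitrogen gives a number 5.3 percentage points lower from compound 2 to compound 3 (within the scatter), the first step that can be read at this position. Moving the chlorine around this ring therefore leaves no difference that this read-out can separate from repeat-to-repeat variation, and compound 2 and compound 3 have to be treated as equivalent here. No measurement shown offers an explanation for this result.

Compound 1, the carboxylic acid, carries no number, so the step from it to either amide cannot be read. On these data alone, whether an unsubstituted phenyl, a 4-methoxyphenyl or a benzyl on the same nitrogen would stand apart from the two chlorophenyl amides remains open, as does the effect of a shorter or longer chain leading to the amide.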